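Swapping a side chain in a cytotoxicity series

A few compounds are considered here, and "the series" means these few. Any claim that something is new, unique, unknown or untested is made for them only; others in the source may bear on it.

Compound 1 `COc1cc(C(c2ccc(O)c(OC)c2)[C@H](C)[C@H](C)CO)ccc1O` gives > 100000 nM (a limit)
Compound 2 `COC[C@H](C)[C@@H](C)C(c1ccc(O)c(OC)c1)c1ccc(O)c(OC)c1` gives 68000 nM
Compound 3 `COc1cc(C(c2ccc(O)c(OC)c2)[C@@H](CO)C(C)C)ccc1O` gives > 100000 nM (a limit)

In a functional assay on HL-60 cells (Homo sapiens) for cytotoxicity, read by WST assay, with a stated time of 48 h (a higher number here means a weaker inhibitor, a lower number a stronger inhibitor), compound 3 reports > 100000 nM as a limit, not a number. The series leans heavily on the limit of > 100000 nM in this assay, at which 2 of the 3 values shown sit, and so offers little to measure from. Compound 4 `COc1cc(C(c2ccc(O)c(OC)c2)[C@@H](C)[C@H](C)CO)ccc1O` has not yet been measured, and it differs from compound 3 as follows: 2-(hydroxymethyl)-1-methylpropyl in place of 1-(hydroxymethyl)-2-methylpropyl on a saturated chain carbon bound to two aromatic carbons on a saturated chain carbon bound to two aromatic carbons.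

The closest evidence is a step that the two limits leave unreadable from compound 1 to compound 3 and it swaps the same two groups the opposite way, without giving a size. The other two steps, an at least 1.4-fold lower number from compound 1 to compound 2 (0.16 log units; that floor lies within the scatter) and an at least 1.4-fold higher number from compound 2 to compound 3 (0.16 log units; that floor lies within the scatter), involve a methoxymethyl group that compound 4 lacks, and their floors lie within the scatter. Only compound 2 gives a true number, 68000 nM in this case.

The expected change is a number no higher from compound 3 to compound 4 (the limit leaves the size open) in this assay and none beyond the scatter is anticipated. The estimate for compound 4 is 100000 nM within an expected range of 50000 nM to 200000 nM for this measurement.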

Compound 4, half-maximal inhibitory concentration: > 100000 nM
Compound 4: only a limit was reported (the forecaster's own chance of this, stated with the estimate: 70%); the middle value lies on the limit itself.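

In this assay compound 4 gives > 100000 nM, which is a limit and not a number. The steps that reach compound 4 from compound 1 and from compound 3 cannot be read, so neither the swap on a saturated chain carbon bound to two aromatic carbons nor the change in drawn configuration gains a size: the fact that compounds 1 and 4 differ only in the configuration as drawn. Among the compounds shown here, the only step that can be read is an at least 1.4-fold higher number from compound 2 to compound 4 (0.16 log units; that floor lies within the scatter), and this floor sets no upper size on the change, since the series rests mostly on one limit: the limit of > 100000 nM in this assay, at which 3 of the 4 values shown sit.

As far as these compounds go, how far the true values of compound 1, compound 3 and compound 4 lie past that limit stays open, as does their order. Also open, from the compounds shown here alone, is what an amine or a carboxylic acid in place of the hydroxymethyl would give in this assay.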